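From Nitro to Fluoro on the Methoxyphenyl Ring

A few compounds are considered here, and "the series" means these few. Any claim that something is new, unique, unknown or untested is made for them only; others in the source may bear on it.

In a functional assay on A549 cells (Homo sapiens) for antiproliferative activity, read by sulforhodamine B assay, with a stated time of 48 h (on this read-out higher numbers stand for weaker inhibition and lower numbers for stronger inhibition), compound 3 `COc1ccc2nc(-c3ccc(N/C=C\C(=O)c4ccc(OC)c([N+](=O)[O-])c4)cc3)sc2c1` gives 13600 nM. Compound 1 `COc1ccc2nc(-c3ccc(N/C=C\C(=O)c4ccc(OC)c(O)c4)cc3)sc2c1` gives 12800 nM, level with compound 3 within the scatter. Both numbers stand well above that of compound 2 `COc1ccc2nc(-c3ccc(N/C=C\C(=O)c4ccc(OC)c(F)c4)c(C)c3)sc2c1`, at 1400 nM.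

The next compound, compound 4 `COc1ccc2nc(-c3ccc(N/C=C\C(=O)c4ccc(OC)c(F)c4)cc3)sc2c1`, has fluoro in place of nitro on an aromatic carbon, ortho to a methoxy group: fluoro in place of nitro on an aromatic carbon.

Among the compounds with values here, only one measured step touches this site. It is a 1.1-fold higher number from compound 1 to compound 3 (0.03 log units; within the scatter), with nitro in place of hydroxy, and it stays within the scatter. That step alone would suggest little movement. However, the 3-fluoro-4-methoxyphenyl group of compound 4 is already present in compound 2, which gives 1400 nM but also carries an extra methyl group. Within the data shown here, no measured step separates the share of the fluoro group from that of the methyl group. A moderate move towards stronger inhibition in this assay is therefore expected, probably smaller than the whole gap to compound 2, though no change at all remains possible.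

The expected move is a 3.0-fold lower number from compound 3 to compound 4 (0.48 log units; beyond the scatter). Compound 4 is estimated at 4500 nM, with an expected range from 1300 nM to 14000 nM.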

Compound 4, half-maximal inhibitory concentration: 900 nM
Estimate against measurement, compound 4: 5.0-fold (0.70 log units) above; the measured number lies below the stated range.
By their numbers in this assay, from the lowest: compounds 4 and 2 (each within the scatter of the next); then compounds 1 and 3 (each within the scatter of the next).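

In this assay, the position ortho to a methoxy group turns out to respond strongly to what sits on it, which the earlier swap of hydroxy for nitro could not show: fluoro in place of nitro gives a 15-fold lower number from compound 3 to compound 4 (1.18 log units; beyond the scatter), and fluoro in place of hydroxy gives a 14-fold lower number from compound 1 to compound 4 (1.15 log units; beyond the scatter), so the two large steps agree and set fluoro apart from both other groups. The methyl group of compound 2 can now be read on its own, and hydrogen in its place gives a 1.6-fold lower number from compound 2 to compound 4 (0.19 log units; within the scatter), a step within the scatter, so this pair shows no measurable contribution from that methyl group and places the 3-fluoro-4-methoxyphenyl compounds level with each other. Nothing available here explains why fluoro stands apart from nitro and hydroxy on this ring.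

Within the data shown here, with only three groups compared at this position, it remains open whether the gain belongs to fluoro alone or would also appear with hydrogen, chloro or an amine there. As far as these compounds go, it is equally open whether a chloro or an ethyl group in place of the methyl of compound 2 would stay level with compound 4.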